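A few compounds are considered here, and "the series" means these few. Any claim that something is new, unique, unknown or untested is made for them only; others in the source may bear on it.

Measured compounds in an assay on isolated protein with Bile acid receptor (Homo sapiens) as the target; on this read-out higher numbers stand for an effect only at larger amounts of compound and lower numbers for an effect already at smaller amounts:
compound 1, `COC(=O)/C=C/c1cccc(N(Cc2ccc(C(C)(C)C)cc2)C(=O)C2CCCCC2)c1`, > 1000 nM
compound 2, `CCOC(=O)/C=C/c1ccc(CN(C(=O)C2CCCCC2)c2cccc(/C=C/C(=O)OC)c2)cc1`, > 1000 nM
compound 3, `COC(=O)/C=C/c1cccc(N(Cc2ccc(/C=C/C(=O)O)cc2)C(=O)C2CCCCC2)c1`, > 1000 nM

Each of these three values is a limit of this assay, not a number. For compound 3 the result in this assay is only such a limit. The same holds for compound 1, and for compound 2. All three sit at the limit of > 1000 nM in this assay, at which 3 of the 3 values shown sit. The three measured steps give no readable size: a step that the two limits leave unreadable from compound 1 to compound 2, a step that the two limits leave unreadable from compound 1 to compound 3 and a step that the two limits leave unreadable from compound 2 to compound 3 all remain hidden behind the limits.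

Compound 4, `COC(=O)/C=C/c1cccc(N(Cc2ccc(/C=C/c3c(Cl)cccc3Cl)cc2)C(=O)C2CCCCC2)c1`, is not yet measured. It differs from compound 3 by 2,6-dichlorophenyl in place of carboxy on a double-bonded chain carbon bound to a double-bonded chain carbon. Going by the values given here, none of the measured steps touches this kind of change; the closest are the steps from compound 1 that exchange tert-butyl for an ester or an acid on the aromatic carbon, and their size is unreadable. The expected step that the limit leaves unreadable from compound 3 to compound 4 therefore rests on little, and the change could go in either direction. For compound 4 the estimate in this assay is 2000 nM, with a range from 300 nM to 10000 nM, and a real chance that only a limit is reported again.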

Compound 4, half-maximal effective concentration: 150 nM
For compound 4 the middle estimate is 13-fold (1.12 log units) above the measured one; measured number below the stated range.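

In this assay this position proves able to move the read-out, as compound 4 alone gives a number and the rest remain at a limit of the assay: the limit of > 1000 nM in this assay, at which 3 of the 4 values shown sit.

With 2,6-dichlorophenyl in place of carboxy on a double-bonded chain carbon bound to a double-bonded chain carbon, the result is an at least 6.6-fold lower number from compound 3 to compound 4 (0.82 log units; beyond the scatter), and the same group in place of ethoxycarbonyl at that place gives an at least 6.6-fold lower number from compound 2 to compound 4 (0.82 log units; beyond the scatter). Going by these compounds alone, measured against the tert-butyl group, 2-(2,6-dichlorophenyl)ethenyl on an aromatic carbon gives an at least 6.6-fold lower number from compound 1 to compound 4 (0.82 log units; beyond the scatter), whereas the steps among compound 1, compound 2 and compound 3 cannot be read, so an aromatic ring carried on the ethenyl chain is the only change here with a readable effect.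

The compounds shown do not separate the contribution of the ring from that of its two chlorines, which a plain phenyl or a phenyl with one chlorine would address. Going by these compounds, whether the methyl ester shared by all four compounds can give way to a carboxylic acid while keeping the 2-(2,6-dichlorophenyl)ethenyl group also remains open.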